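Hydrogen to methyl on the side chain, two cores

A few compounds are considered here, and "the series" means these few. Any claim that something is new, unique, unknown or untested is made for them only; others in the source may bear on it.

Compound 1 `CCn1nc(-c2ccnc(Nc3ccc(S(N)(=O)=O)cc3)n2)c2ccccc21` gives 2050 nM in a functional assay on HCT-116 cells (Homo sapiens) for antiproliferative activity, read by MTT assay, with a stated time of 72 h; on this read-out higher numbers stand for weaker inhibition of growth and lower numbers for stronger inhibition of growth. Compound 2 `CCCn1nc(-c2ccnc(Nc3ccc(S(N)(=O)=O)cc3)n2)c2ccccc21` differs from compound 1 by methyl in place of hydrogen on a saturated chain carbon, two bonds along the chain from an aromatic nitrogen; in this assay compound 2 gives 6740 nM, and the step is a 3.3-fold higher number from compound 1 to compound 2 (0.52 log units; beyond the scatter). Compound 3 `Cc1nn(-c2ccnc(Nc3ccc(S(N)(=O)=O)cc3)n2)c2ncccc12` has a different core; the difference between the two cores is not broken down here. In this assay compound 3 gives 8840 nM, a number that against compound 2 lies within the scatter and against compound 1 lies beyond it, higher.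

Compound 4 `CCc1nn(-c2ccnc(Nc3ccc(S(N)(=O)=O)cc3)n2)c2ncccc12` is not yet measured. It differs from compound 3 by methyl in place of hydrogen on a saturated chain carbon bound to an aromatic carbon. This is the same kind of change as from compound 1 to compound 2, not the same: there the place was on a saturated chain carbon, two bonds along the chain from an aromatic nitrogen; here it is on a saturated chain carbon bound to an aromatic carbon. Among the compounds with values here, the expected step is a 1.8-fold higher number from compound 3 to compound 4 (0.26 log units; within the scatter) in this assay, resting on the single earlier step of a 3.3-fold higher number from compound 1 to compound 2 (0.52 log units; beyond the scatter) in the other core, weighed down for the differing place. Compound 4 is estimated at 16000 nM, expected between 6000 nM and 40000 nM.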

Compound 4, concentration for 50% growth inhibition: 6340 nM
Compound 4: the middle estimate sits 2.5-fold (0.40 log units) above what was measured, within the range that was stated.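

In this assay the swap of hydrogen for methyl gives a 1.4-fold lower number from compound 3 to compound 4 (0.14 log units; within the scatter), and this does not match the step on the other core: the same change on two cores in this assay, a 3.3-fold higher number (0.52 log units; beyond the scatter) from compound 1 to compound 2 and a 1.4-fold lower number (0.14 log units; within the scatter) from compound 3 to compound 4, 4.6-fold (0.66 log units) apart, beyond the scatter of two such steps

On these two pairs, then, the size of the step seen on the core of compound 1 does not carry over to the core of compound 3, so a step read on one core is a poor guide to the other in this series. This does not show whether the core or the place of the change accounts for the gap; in one pair the place is a saturated chain carbon two bonds along the chain from an aromatic nitrogen, and in the other it is a saturated chain carbon bound to an aromatic carbon.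

Still open, going by these compounds, is whether the change at one and the same place on both cores would give matching steps. Also open, on these data alone, is how a butyl chain, an amine or a carboxylic acid would read on either core.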